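The source may report more compounds than this note shows. Statements on the series, on what has been measured and on what is new or still open speak of the compounds shown alone.

Compound 1 `Oc1nc(-c2cccc(F)c2)sc1-c1nn[nH]n1` carries the unsubstituted 2H-tetrazol-5-yl group. In an assay on HEK293 cells for inhibition of transient receptor potential cation channel subfamily M member 8 (Homo sapiens), read by FLIPR, with stated times of 5 min and 3 min (a higher number here means a weaker inhibitor, a lower number a stronger inhibitor), compound 1 gives only a limit, > 100000 nM, so no number is known for it. It sits at the limit of > 100000 nM in this assay, at which 1 of the 2 values shown sits. Compound 2 `CCn1nnc(-c2sc(-c3cccc(NC)c3)nc2O)n1` gives 1020 nM in this assay. Going by the values given here, compound 2 is not a single-change partner of compound 1; the two values show only that one member of the series returns a number while compound 1 does not. Compound 3 `Cn1nnc(-c2sc(-c3cccc(F)c3)nc2O)n1` is compound 1 with methyl in place of hydrogen on an aromatic nitrogen. Among the compounds with values here, no measured pair covers this change on its own, so the size of the step rests on expectation alone. The step of an at least 12-fold lower number from compound 1 to compound 3 (1.09 log units; beyond the scatter) is expected to run toward stronger inhibition and beyond the scatter, given that compound 2 gives 1020 nM while compound 1 sits at the limit of > 100000 nM in this assay, at which 1 of the 2 values shown sits. Compound 3 is therefore estimated at 8000 nM, with a range from 1500 nM to 60000 nM.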

Compound 3, half-maximal inhibitory concentration: 214 nM
Beside the measured number, compound 3's estimate is 37-fold (1.57 log units) above it, and the stated range ends above it.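

In this assay, methyl in place of hydrogen on an aromatic nitrogen gives an at least 460-fold lower number from compound 1 to compound 3 (2.66 log units; beyond the scatter), so this single change on the core of compound 1 is now seen on its own and is large. With the methyl group on this nitrogen, between two ring nitrogen atoms, compound 3 returns a number, 214 nM. The step gives a bound on the size of the change and not an exact size, as compound 1 gives only a limit and not a number: the limit of > 100000 nM in this assay, at which 1 of the 3 values shown sits.

From the compounds shown here alone, how a longer chain such as propyl, or a chain ending in an amine or a carboxylic acid, would read at this nitrogen stays open. Also open, going by these compounds, is whether a step of this size would hold with a different group in place of the 3-fluorophenyl ring.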